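Swapping a Chain for Chlorine at One Aromatic Carbon

The source may report more compounds than this note shows. Statements on the series, on what has been measured and on what is new or still open speak of the compounds shown alone.

The measured compounds and their values:
- Compound 1, `COc1ccc(N2CCN(c3cc(C(F)(F)F)ccc3CNC(=O)C(C)c3ccc(NS(C)(=O)=O)c(F)c3)CC2)cc1`: 1.6 nM
- Compound 2, `CC(C)CCOc1cc(C(F)(F)F)ccc1CNC(=O)C(C)c1ccc(NS(C)(=O)=O)c(F)c1`: 0.5 nM
- Compound 3, `C[C@H](C(=O)NCc1ccc(C(F)(F)F)cc1SC1CCCCC1)c1ccc(NS(C)(=O)=O)c(F)c1`: 0.3 nM

All three were tested in an assay on CHO cells for antagonist activity at transient receptor potential cation channel subfamily V member 1 (Homo sapiens), read by FLIPR; a lower number here means a stronger inhibitor, a higher number a weaker inhibitor. Compound 2 sits second highest of the three numbers. Its nearest neighbour is compound 3, whose value lies within the usual scatter of compound 2, so the two cannot be told apart. Compound 1 stands further away, with a number beyond the scatter above compound 2.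

Compound 4, `CC(C(=O)NCc1ccc(C(F)(F)F)cc1Cl)c1ccc(NS(C)(=O)=O)c(F)c1`, has not yet been measured. It differs from compound 2 in one place: chloro in place of isopentyloxy on an aromatic carbon. Among the compounds with values here, each of the three measured compounds carries a sizeable group at this aromatic carbon, and every one of them gives a low number; compound 4 is the first in which that place holds only a single chlorine atom. Within the data shown here, there is no measured pair showing what such a change does here, so the expectation rests on the shared pattern rather than a direct precedent.

The step from compound 2 is expected to be a rise, a 16-fold higher number from compound 2 to compound 4 (1.20 log units; beyond the scatter), likely beyond the scatter. Compound 4 is estimated to give 8 nM, within a range from 2 nM to 40 nM.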

Compound 4, inhibition constant: 4 nM
Compound 4: middle estimate off by 2.0-fold (0.30 log units), on the high side, and the stated range covers the measured number.
By their numbers in this assay, from the lowest: compounds 3 and 2 (each within the scatter of the next); then compound 1; then compound 4.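

In this assay, within the data shown here, replacing the isopentyloxy chain of 6 heavy atoms with a chloro group of 1 heavy atom gives an 8.0-fold higher number from compound 2 to compound 4 (0.90 log units; beyond the scatter), the first step that can be read at this aromatic carbon, and it shows that the number depends on what this carbon carries. The same result also shows that a large group here is not needed for inhibition, since compound 4, with only a chlorine atom at this carbon, still gives 4 nM. Nothing measured here bears on why the number rises with this change.

The compounds shown leave open how the number behaves with groups of intermediate length at this carbon, such as a methoxy or an ethoxy group, and whether a fluorine atom or a methyl group would give a number close to that of the chloro group. They also leave open what an amine or a carboxylic acid at this same carbon would do, as every group seen here so far lacks a hydrogen-bond donor.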